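This account rests on a few compounds, and the source may have more. Where it says the series, first, only, none or still open, it means among the compounds named here.

Measured compounds and their values:
- compound 1 `Cc1ccc(SCc2ccc(C(=O)Nc3ccccc3N)cc2)cc1`: 84%
- compound 2 `Nc1ccccc1NC(=O)c1ccc(CSc2ccc(F)cc2)cc1`: 90.6%

In a functional assay on HCT-116 cells (Homo sapiens) for inhibition, read by CCK-8 assay, with a stated time of 72 h, tested at 8 uM (on this read-out higher numbers stand for more inhibition of growth at the one concentration tested and lower numbers for less inhibition of growth), compound 2 stands at 90.6% and lies within the scatter of compound 1, so the two cannot be ranked. Compound 3 `Cc1cc(C)cc(SCc2ccc(C(=O)Nc3ccccc3N)cc2)c1` has not yet been measured. It differs from compound 2 as follows: 3,5-dimethylphenyl in place of 4-fluorophenyl on a sulfur. For the measured compounds named here, one measured step bears on this change: a number 6.6 percentage points higher from compound 1 to compound 2 (within the scatter), for fluoro in place of methyl on an aromatic carbon, and it stayed within the scatter. Going by the values given here, no measured compound yet carries the 3,5-dimethylphenyl group. In this assay a shift beyond the scatter is therefore not expected, in either direction. The estimated step is a number 6.6 percentage points lower from compound 2 to compound 3 (within the scatter) and is expected to stay within the scatter. Compound 3 is estimated at 84%, with an expected range from 72% to 93%.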

Compound 3, percent growth inhibition at one concentration: 72.9%
Compound 3: the middle estimate sits 11.1 percentage points above what was measured; low and high end bracket the measured number.
By their numbers in this assay, from the lowest: compound 3; then compounds 1 and 2 (each within the scatter of the next).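

In this assay, the group on the sulfur proves able to move the read-out beyond the scatter: 3,5-dimethylphenyl in place of 4-fluorophenyl gives a number 17.7 percentage points lower from compound 2 to compound 3 (beyond the scatter) and 3,5-dimethylphenyl in place of 4-methylphenyl gives a number 11.1 percentage points lower from compound 1 to compound 3 (beyond the scatter). The earlier exchange of 4-methylphenyl and 4-fluorophenyl had not shown this, as it stayed within the scatter, whereas both steps to the 3,5-dimethylphenyl group now point the same way. Nothing available explains why the number falls with this group.

The 3,5-dimethylphenyl group differs from 4-methylphenyl in both the number of methyl groups and where they stand, and the compounds shown do not separate the two. As far as these compounds go, how an unsubstituted phenyl, a 3-methylphenyl or a pyridyl ring on the sulfur would read also remains open.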